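The source may hold more compounds than are shown below. What is called first, only, known or untested is meant among the compounds shown, and "the series" means these compounds.

Compound 1 `COc1cc2c(/C=C3/C(=O)Nc4ccc(O)cc43)c(Cl)n(Cc3cc(OC)c(OC)c(OC)c3)c2cc1C` in a functional assay on NSCLC cells (Homo sapiens) for cytotoxicity, with a stated time of 48 h (on this read-out higher numbers stand for weaker inhibition of growth and lower numbers for stronger inhibition of growth), gives 32400 nM. Compound 2 `O=C1Nc2ccccc2/C1=C\c1c(Cl)n(Cc2ccccc2)c2ccccc12` in this assay gives 57500 nM. Compound 1 stands at the lower of the two numbers, but the gap to compound 2 lies within the scatter, so no order is drawn between them. Compound 3 `COc1cc2c(/C=C3/C(=O)Nc4cccc(Cl)c43)c(Cl)n(Cc3cc(OC)c(OC)c(OC)c3)c2cc1C` differs from compound 1 by a group of 12 heavy atoms (9 carbon, 1 nitrogen, 1 oxygen, 1 chlorine; one five-membered non-aromatic ring with 1 hetero atom, one six-membered aromatic ring of carbon only) in place of a group of 12 heavy atoms (9 carbon, 1 nitrogen, 2 oxygen; one five-membered non-aromatic ring with 1 hetero atom, one six-membered aromatic ring of carbon only), on an aromatic carbon. Within the data shown here, no single-change step within the measured pair exists to guide the size of this move, so no shift beyond the scatter is expected. Compound 3 is therefore estimated at 30000 nM, in the range 10000 nM to 90000 nM, a step of a 1.1-fold lower number from compound 1 to compound 3 (0.03 log units; within the scatter).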

Compound 3, concentration for total growth inhibition: 12000 nM
Compound 3: middle estimate off by 2.5-fold (0.40 log units), on the high side, within the range that was stated.
By their numbers in this assay, from the lowest: compound 3; then compounds 1 and 2 (each within the scatter of the next).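

In this assay, among these compounds, the exchange on this aromatic carbon gives the first step beyond the scatter: a 2.7-fold lower number from compound 1 to compound 3 (0.43 log units; beyond the scatter). The group entering carries 1 chlorine, 1 hydrogen-bond donor and 1 hydrogen-bond acceptor, and the group leaving carries 2 hydrogen-bond donors and 2 hydrogen-bond acceptors, so these differences cannot be separated from one another here. Nothing on hand accounts for the step. From the compounds shown here alone, whether the chlorine alone carries the step remains open. Going by these compounds, the outcome with an amine or a carboxylic acid in its place is also open.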